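Swapping a nitro group for a hydroxyl on a chalcone

The compounds below may be only part of what the source reports. "The series", "measured", "known", "first", "only" and "open" are said of these compounds alone.

Of the compounds shown here, three built on one shared core have been tested in a functional assay on HT-29 cells (Homo sapiens) for antiproliferative activity, read by MTT assay, with a stated time of 24 h; on this read-out higher numbers stand for weaker inhibition and lower numbers for stronger inhibition. Compound 1, `COc1ccc(C(=O)/C=C/c2cc(OC)c(OC)c(OC)c2)c2c1C=CC(C)(C)O2`, gives only a limit of this assay, > 10000 nM. Compound 2, `COc1ccc(C(=O)/C=C/c2ccc3ccccc3n2)c2c1C=CC(C)(C)O2`, gives 3790 nM in this assay. Compound 3, `COc1ccc(C(=O)/C=C/c2ccc([N+](=O)[O-])cc2)c2c1C=CC(C)(C)O2`, gives 3730 nM in this assay. The numbers for compound 3 and compound 2 lie so close together that no difference between them can be claimed, and with compound 1 known only as a limit, compound 3 simply stands level with compound 2 among the values on hand.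

Compound 4, `COc1ccc(C(=O)/C=C/c2cccc(O)c2)c2c1C=CC(C)(C)O2`, has not yet been measured. It differs from compound 3 in one place: 3-hydroxyphenyl in place of 4-nitrophenyl on a double-bonded chain carbon bound to a double-bonded chain carbon. A 3-hydroxyphenyl enters where a 4-nitrophenyl leaves, on a double-bonded chain carbon bound to a double-bonded chain carbon. Among the compounds with values here, no two measured compounds differ in only one place, so there is no measured step to lean on for this change.

The expected step of a 1.3-fold higher number from compound 3 to compound 4 (0.13 log units; within the scatter) is small, a slight move toward weaker inhibition that may not rise beyond the scatter. Compound 4 is expected to give 5000 nM in this assay, within a range from 1500 nM to 15000 nM.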

Compound 4, half-maximal inhibitory concentration: > 10000 nM
Compound 4 was reported as a limit; the forecaster's own chance of this, stated with the estimate: 25%; at least 2.0-fold (0.30 log units) between middle value and limit.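

This is the first one-place change that can be read among these compounds. In this assay, 3-hydroxyphenyl in place of 4-nitrophenyl on a double-bonded chain carbon bound to a double-bonded chain carbon gives an at least 2.6-fold higher number from compound 3 to compound 4 (0.42 log units; beyond the scatter), so the group at this place matters and the two groups cannot be exchanged without a loss of inhibition. The full size of this step stays unknown, as compound 4 is reported only as a limit, the same limit that compound 1 reaches: the limit of > 10000 nM in this assay, at which 2 of the 4 values shown sit.

Going by these compounds, the step changes two things at once, the kind of group on the ring and the name of its ring position, so it remains open which of the two counts, and a 4-hydroxyphenyl or a 3-nitrophenyl at this place would separate them. On these data alone, it is also open whether another group on this ring, such as an amine or a carboxylic acid, would stay level with compound 3 or fall away as compound 4 does, and no cause for the loss can be drawn from these values.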